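A few compounds are considered here, and "the series" means these few. Any claim that something is new, unique, unknown or untested is made for them only; others in the source may bear on it.

Working values in a functional assay on a subcellular fraction from brain (Rattus norvegicus) for inhibition, read by scintillation counting, with a stated time of 5 min; on this read-out lower numbers stand for stronger inhibition and higher numbers for weaker inhibition:

- compound 1 `Clc1ccc(NC2=NCCC3(CCCCC3)S2)cc1`: 35500 nM
- compound 2 `FC(F)(F)c1ccc(NC2=NCCC3(CCCCC3)S2)cc1`: 77600 nM
- compound 3 `CC(C)c1ccc(NC2=NCCC3(CCCCC3)S2)cc1`: 6200 nM

Compound 1 stands second highest of the three numbers; its nearest neighbour is compound 2, with a 2.2-fold higher number from compound 1 to compound 2 (0.34 log units; beyond the scatter), and its furthest is compound 3, with a 5.7-fold lower number from compound 1 to compound 3 (0.76 log units; beyond the scatter). The widest spread in the set is a 13-fold lower number from compound 2 to compound 3 (1.10 log units; beyond the scatter).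

The next compound is compound 4 `COc1ccc(NC2=NCCC3(CCCCC3)S2)cc1`, which differs from compound 1 by methoxy in place of chloro on an aromatic carbon.

Bearing on this step are the two changes already measured at the same aromatic carbon: trifluoromethyl in place of chloro gave a modest rise in the number, isopropyl in place of chloro gave a modest fall. Neither involves methoxy, so the set gives no direct guide for it, and the three measured groups span the range shown above. With nothing closer to go on, the expectation for compound 4 is a number not far from compound 1, if anything somewhat lower, and the step is estimated as a 1.8-fold lower number from compound 1 to compound 4 (0.25 log units; within the scatter). The estimate for compound 4 is therefore 20000 nM, with a range from 5000 nM to 80000 nM.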

Compound 4, half-maximal inhibitory concentration: 85100 nM
Estimate against measurement, compound 4: 4.3-fold (0.63 log units) below; the whole stated range lies below it.
By their numbers in this assay, from the lowest: compound 3; then compound 1; then compounds 2 and 4 (each within the scatter of the next).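

In this assay, methoxy on this aromatic carbon, para to a large group, does not follow isopropyl in lowering the number relative to chloro: it gives a rise (a 2.4-fold higher number from compound 1 to compound 4 (0.38 log units; beyond the scatter)) and lands level with trifluoromethyl (a 1.1-fold higher number from compound 2 to compound 4 (0.04 log units; within the scatter)), so these two groups cannot be told apart at this position. The second large step in the set (a 14-fold higher number from compound 3 to compound 4 (1.14 log units; beyond the scatter)) shows that the isopropyl result stands apart, with compound 3 now the most potent of the four, and isopropyl is the only one of the three replacements for chloro that lowers the number, while compound 2 and compound 4 both go against any general fall on leaving chloro. No measurement of any property of these groups accompanies the values, and the order of the four stands without an explanation.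

On these data alone, whether the fall seen with isopropyl extends to other alkyl groups, such as ethyl, tert-butyl or cyclopropyl, remains open, and so does whether it depends on branching at all. As far as these compounds go, how an amine, a carboxylic acid or a hydroxyl group would behave on this carbon also remains open, as does whether the same order of groups would hold on a different core.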